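Swapping the nitro group for a hydroxycyclohexylamino group

A few compounds are considered here, and "the series" means these few. Any claim that something is new, unique, unknown or untested is made for them only; others in the source may bear on it.

In an assay for inhibition of Indoleamine 2,3-dioxygenase 1 (Homo sapiens), with stated times of 10 min and 60 min, tested at 100 uM (a lower number here means a weaker effect, a higher number a stronger effect of the compound at the concentration tested), compound 3 `O=[N+]([O-])c1cccc(CNc2cc(C(F)(F)F)cc3[nH]ncc23)c1` gives 69%, the second highest of the three numbers measured. Compound 2 `O=[N+]([O-])c1ccccc1CNc1cc(C(F)(F)F)cc2[nH]ncc12` gives 76%, which lies within the scatter of compound 3. Compound 1 `NCCn1ncc2c(NCc3ccccc3[N+](=O)[O-])cc(C(F)(F)F)cc21` gives 30%, clearly lower. For the measured compounds named here, the only measured step between neighbours, a number 46 percentage points higher from compound 1 to compound 2 (beyond the scatter), is a change on an aromatic nitrogen and so does not bear on the change considered here. Compound 4 `OC1CCCC(Nc2cccc(CNc3cc(C(F)(F)F)cc4[nH]ncc34)c2)C1` differs from compound 3 by (3-hydroxycyclohexyl)amino in place of nitro on an aromatic carbon. Going by the values given here, no measured step tests such a change, so the step expected is a number 4 percentage points lower from compound 3 to compound 4 (within the scatter), nothing beyond the scatter. Compound 4 is therefore estimated at 65%, with a range from 35% to 90%.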

Compound 4, a percentage reported as inhibition, at one concentration (the size of the read-out at that concentration, not a potency): 2%
Estimate against measurement, compound 4: 63 percentage points above, and the stated range ends above it.
By their numbers in this assay, from the lowest: compound 4; then compound 1; then compounds 3 and 2 (each within the scatter of the next).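

For the compounds shown here, all the earlier compounds carry nitro, so they could not show how much this aromatic carbon, meta to a large group, depends on that group. The step, a number 67 percentage points lower from compound 3 to compound 4 (beyond the scatter), shows that this replacement is not tolerated here: (3-hydroxycyclohexyl)amino leaves almost no inhibition at the concentration tested. No measurement here explains this loss. The compounds shown leave open whether the loss follows from the carbon ring, the hydroxyl or the linking nitrogen. A plain amino group or an unsubstituted cyclohexylamino group at this position would help separate these parts.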